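The compounds below may be only part of what the source reports. "The series", "measured", "known", "first", "only" and "open" are said of these compounds alone.

Compound 1 `O=C(NCCNS(=O)(=O)c1ccc(-c2ccccc2Oc2ccc([N+](=O)[O-])c([N+](=O)[O-])c2)s1)Nc1cc(Cl)cc(Cl)c1` gives 2100 nM
Compound 2 `O=C(NCCNS(=O)(=O)c1ccc(-c2ccccc2O[C@H]2CC[C@H](O)CC2)s1)Nc1cc(Cl)cc(Cl)c1` gives 14100 nM

In a functional assay on RS4-11 cells (Homo sapiens) for inhibition, read by CCK-8 assay, with a stated time of 48 h (a higher number here means a weaker inhibitor, a lower number a stronger inhibitor), compound 1 holds the lower of the two numbers. Among the compounds with values here, the one measured step is a 6.7-fold higher number from compound 1 to compound 2 (0.83 log units; beyond the scatter) and it puts 4-hydroxycyclohexyl in place of 3,4-dinitrophenyl on an oxygen on an aromatic ring. Compound 3 `COc1cccc(NC(=O)NCCNS(=O)(=O)c2ccc(-c3ccccc3Oc3ccc([N+](=O)[O-])c([N+](=O)[O-])c3)s2)c1` keeps the 3,4-dinitrophenyl and differs from compound 1 elsewhere. The difference is 3-methoxyphenyl in place of 3,5-dichlorophenyl on an amide-type nitrogen and it puts 3-methoxyphenyl in place of 3,5-dichlorophenyl on an amide-type nitrogen. Within the data shown here, no measured step touches that place, so the step above offers only a rough size, and the direction is a cautious expectation toward a higher number in this assay for this change. Compound 3 is estimated at 4500 nM with an expected span from 1300 nM to 15000 nM as the likely range. The expected step is a 2.1-fold higher number from compound 1 to compound 3 (0.33 log units; beyond the scatter) by this estimate.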

Compound 3, half-maximal inhibitory concentration: 1300 nM
The estimate for compound 3 lay 3.5-fold (0.54 log units) above the measured number, within the range that was stated.
By their numbers in this assay, from the lowest: compounds 3 and 1 (each within the scatter of the next); then compound 2.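

In this assay, within the data shown here, this is the first look at the group on the amide-type nitrogen: with the 3,4-dinitrophenyl kept, putting 3-methoxyphenyl in place of 3,5-dichlorophenyl gives a 1.6-fold lower number from compound 1 to compound 3 (0.21 log units; within the scatter). Between these two compounds, then, the exchange leaves no readable difference, whereas the earlier step, at the oxygen on an aromatic ring, went beyond the scatter. Nothing available accounts for this outcome.

As far as these compounds go, whether the amide-type nitrogen accepts other groups, such as an unsubstituted phenyl, a pyridine or a cyclohexyl, remains open. From the compounds shown here alone, it is also open whether 3-methoxyphenyl would behave the same way alongside the 4-hydroxycyclohexyl of compound 2, since this exchange has been read only with the 3,4-dinitrophenyl in place.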